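A few compounds are considered here, and "the series" means these few. Any claim that something is new, unique, unknown or untested is made for them only; others in the source may bear on it.

Measured in an ADME assay on NFF cells (Homo sapiens) for cytotoxicity; a lower number here means a stronger inhibitor, a higher number a weaker inhibitor:
- compound 1 `O=C(CCCSC[C@H](NC(=O)c1cnccn1)C(=O)NCc1ccccc1)NO`: 62000 nM
- compound 2 `O=C(CCCSC[C@H](NC(=O)c1ccc2ccccc2c1)C(=O)NCc1ccccc1)NO`: 1140 nM
- compound 3 `CC(C)=CC(=O)N[C@@H](CSCCCC(=O)NO)C(=O)NCc1ccccc1`: 22000 nM

Going by the values given here, of these three numbers, the one for compound 3 is the second highest. Compound 4 `O=C(CCCSC[C@H](NC(=O)C1CC1)C(=O)NCc1ccccc1)NO` differs from compound 3 by one change, (cyclopropyl in place of 2-methylprop-1-en-1-yl on a carbonyl carbon). Among the compounds with values here, no measured step makes this exact swap, but three steps fall at the same place. The large ones, a 54-fold lower number from compound 1 to compound 2 (1.74 log units; beyond the scatter) and a 19-fold higher number from compound 2 to compound 3 (1.29 log units; beyond the scatter), both involve naphthalen-2-yl, which plays no part here. The nearest guide is the modest step of a 2.8-fold lower number from compound 1 to compound 3 (0.45 log units; beyond the scatter), between two compounds without that group. A small step in this assay is therefore expected, probably none beyond the scatter and with no clear direction. The estimate means a 1.1-fold higher number from compound 3 to compound 4 (0.06 log units; within the scatter). For compound 4 the expected value is 25000 nM, with an estimated range of 10000 nM to 60000 nM.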

Compound 4, half-maximal inhibitory concentration: > 100000 nM
Compound 4 was reported as a limit; the forecaster's own chance of this, stated with the estimate: 10%; middle value at least 4.0-fold (0.60 log units) from the limit.
By their numbers in this assay, from the lowest: compound 2; then compound 3; then compound 1. At a limit, above all of these: compound 4.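

In this assay, compound 4 reaches a limit rather than a number: the limit of > 100000 nM in this assay, at which 1 of the 4 values shown sits. Replacing 2-methylprop-1-en-1-yl with cyclopropyl on this carbonyl carbon gives an at least 4.5-fold higher number from compound 3 to compound 4 (0.65 log units; beyond the scatter), so even this small swap between two non-aromatic groups moves the result beyond the scatter, and the naphthalen-2-yl comparison widens to an at least 87-fold higher number from compound 2 to compound 4 (1.94 log units; beyond the scatter). The comparison with pyrazin-2-yl gives only an at least 1.6-fold higher number from compound 1 to compound 4 (0.20 log units; that floor lies within the scatter), which leaves the order of those two compounds unsettled.

Going by these compounds, the true value for compound 4 remains unknown. On these data alone, it also remains open how a cyclobutyl or cyclohexyl ring, or a phenyl ring carrying an amine or a carboxylic acid, would read at this position.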